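The source may hold more compounds than are shown below. What is called first, only, known or untested is meant among the compounds shown, and "the series" means these compounds.

Among the measured compounds shown here, in an in vitro ADME assay on microsomes from liver (Homo sapiens) for metabolic stability (a lower number here means slower removal, a higher number faster removal of the compound), compound 2 `CC(C)Nc1nccc(-c2c[nH]nc2-c2ccc(Cl)cc2)n1` gives 0.106 mL/min/kg, the higher of the two numbers so far, and compound 1 `CC(C)Nc1nccc(-c2c[nH]nc2C2CCCOC2)n1` gives 0.034 mL/min/kg. For the measured compounds named here, the only measured step, a 3.1-fold higher number from compound 1 to compound 2 (0.49 log units; beyond the scatter), is modest but beyond the scatter. Compound 3 `CC(C)Nc1nccc(-c2c[nH]nc2C2CCCNC2)n1` differs from compound 2 as follows: piperidin-3-yl in place of 4-chlorophenyl on an aromatic carbon. This removes the same 4-chlorophenyl group, now with piperidin-3-yl rather than oxan-3-yl in its place, so the measured step is expected to run largely in reverse, toward a lower number. The expected change is a 2.7-fold lower number from compound 2 to compound 3 (0.42 log units; beyond the scatter). For compound 3 the estimated value is 0.04 mL/min/kg, with an expected range of 0.015 mL/min/kg to 0.11 mL/min/kg.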

Compound 3, clearance: 0.014 mL/min/kg
The estimate for compound 3 lay 2.9-fold (0.46 log units) above the measured number; the whole stated range lies above it.
By their numbers in this assay, from the lowest: compound 3; then compound 1; then compound 2.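

In this assay, piperidin-3-yl gives the lowest number of the three, with a 7.6-fold lower number from compound 2 to compound 3 (0.88 log units; beyond the scatter) and a 2.4-fold lower number from compound 1 to compound 3 (0.39 log units; beyond the scatter). The second step shows that this position separates two non-aromatic six-membered rings, and not only an aromatic ring from a non-aromatic one. No measurement shown accounts for this order. On these data alone, it remains open whether the lower number needs the ring nitrogen within a ring: an open-chain amine or a morpholine ring would test this. As far as these compounds go, whether the chlorine of 4-chlorophenyl contributes to the higher number of compound 2 also remains open.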